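From a silent aniline to a benzylic amine

A few compounds are considered here, and "the series" means these few. Any claim that something is new, unique, unknown or untested is made for them only; others in the source may bear on it.

Measured in a functional assay on MCF7 cells (Homo sapiens) for antiproliferative activity; a lower number here means a stronger inhibitor, a higher number a weaker inhibitor:
compound 1 `CCNCCCOc1ccc2cc(NC(=O)c3ccc(O)c(CC=C(C)C)c3)c(=O)oc2c1C`: 980 nM
compound 2 `CC(C)=CCc1cc(C(=O)Nc2cc3ccc(OCCCN(C(C)C)C(C)C)c(C)c3oc2=O)ccc1O`: 1310 nM
compound 3 `CC(C)=CCc1cc(C(=O)Nc2cc3ccc(OCCCN(C)c4ccccc4)c(C)c3oc2=O)ccc1O`: > 50000 nM

For compound 3 the entry > 50000 nM is a limit of the assay, not a number. Compound 4 `CC(C)=CCc1cc(C(=O)Nc2cc3ccc(OCCCN[C@H](C)c4ccccc4)c(C)c3oc2=O)ccc1O` differs from it at one place: (1-phenylethyl)amino in place of methyl(phenyl)amino on a saturated chain carbon, three bonds along the chain from an oxygen on an aromatic ring. Going by the values given here, two measured steps bear on this change: an at least 51-fold higher number from compound 1 to compound 3 (1.70 log units; beyond the scatter) and an at least 38-fold higher number from compound 2 to compound 3 (1.58 log units; beyond the scatter). Both are large, while a 1.3-fold higher number from compound 1 to compound 2 (0.13 log units; within the scatter) stays within the scatter. The entering (1-phenylethyl)amino keeps a phenyl ring, yet its name reads closer to the ethylamino of compound 1 at 980 nM. A large drop in this assay is therefore expected, as an at least 25-fold lower number from compound 3 to compound 4 (1.39 log units; beyond the scatter). For compound 4 the estimated value is 2000 nM, with an expected range of 500 nM to 15000 nM.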

Compound 4, half-maximal inhibitory concentration: 1450 nM
Compound 4: middle estimate off by 1.4-fold (0.14 log units), on the high side; the range from low to high includes it.
By their numbers in this assay, from the lowest: compounds 1, 2 and 4 (each within the scatter of the next). At a limit, above all of these: compound 3.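

Carrying a phenyl ring at this place does not by itself cost activity in this assay: the change gives an at least 34-fold lower number from compound 3 to compound 4 (1.53 log units; beyond the scatter). The entry for compound 3 is a limit of the assay and not a number: the limit of > 50000 nM in this assay, at which 1 of the 4 values shown sits. The other two steps stay within the scatter, a 1.1-fold higher number from compound 2 to compound 4 (0.04 log units; within the scatter) and a 1.5-fold higher number from compound 1 to compound 4 (0.17 log units; within the scatter), so ethylamino, diisopropylamino and (1-phenylethyl)amino are not told apart here, and only compound 3 goes against them.

Open remain what the opposite stereocentre of (1-phenylethyl)amino would give, and whether a benzylamino or a morpholine at this place would fall with these three or with compound 3.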